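The source may report more compounds than this note shows. Statements on the series, on what has been measured and on what is new or still open speak of the compounds shown alone.

Measured so far:
- compound 1 `Cc1ccc(F)cc1NC(=O)CN1CCN(c2nnc(Cc3ccccc3)c3ccccc23)CC1`: 19200 nM
- compound 2 `O=C(CN1CCN(c2nnc(Cc3ccncc3)c3ccccc23)CC1)Nc1cccc(Br)c1`: 1.7 nM
- compound 3 `Cc1ccccc1NC(=O)CN1CCN(c2nnc(Cc3ccccc3)c3ccccc23)CC1`: 17300 nM

In a functional assay on MDA-MB-231 cells (Homo sapiens) for cytotoxicity, read by MTT assay, with a stated time of 72 h (on this read-out higher numbers stand for weaker inhibition and lower numbers for stronger inhibition), compound 1 gives 19200 nM, the highest of the three numbers. Compound 3 sits closest to it: the step of a 1.1-fold lower number from compound 1 to compound 3 (0.05 log units; within the scatter) is within the scatter, so the two cannot be ranked. Going by the values given here, compound 2 is far off, with 1.7 nM; it differs from compound 1 in two places at once, the 3-bromophenyl on the amide-type nitrogen and a pyridinylmethyl in place of benzyl on the shared core, and no single step separates those two changes.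

Compound 4 `O=C(CN1CCN(c2nnc(Cc3ccccc3)c3ccccc23)CC1)Nc1cccc(Br)c1` carries 3-bromophenyl in place of 5-fluoro-2-methylphenyl on an amide-type nitrogen. It thus takes the 3-bromophenyl of compound 2 while keeping the benzyl of compound 1. Only the gap between compound 1 and compound 2 bears on it, and that gap cannot be divided between the two changes. The expected direction in this assay is a lower number, of uncertain size; the step of a 64-fold lower number from compound 1 to compound 4 (1.81 log units; beyond the scatter) is the working estimate. For compound 4 the estimate is 300 nM, with a range from 5 nM to 15000 nM.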

Compound 4, half-maximal inhibitory concentration: 3880 nM
Estimate against measurement, compound 4: 13-fold (1.11 log units) below; low and high end bracket the measured number.
By their numbers in this assay, from the lowest: compound 2; then compound 4; then compounds 3 and 1 (each within the scatter of the next).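

In this assay, 3-bromophenyl on the amide-type nitrogen gives a modest but real change on its own (a 4.9-fold lower number from compound 1 to compound 4 (0.69 log units; beyond the scatter); a 4.5-fold lower number from compound 3 to compound 4 (0.65 log units; beyond the scatter)), so this position affects the read-out while the benzyl stays in place. The exchange of pyridin-4-yl for phenyl can now be read alone with 3-bromophenyl held constant (a 2300-fold higher number from compound 2 to compound 4 (3.36 log units; beyond the scatter)), and this step is far larger than either step at the amide-type nitrogen. No measured evidence accounts for either change.

From the compounds shown here alone, whether the pyridin-4-yl step is as large with 5-fluoro-2-methylphenyl or 2-methylphenyl on the amide-type nitrogen stays open. Also open, going by these compounds, is whether an amine or a carboxylic acid in place of pyridin-4-yl would keep a number this low.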